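Pyridinyl for methylpyrazolyl on the amide nitrogen

The source may report more compounds than this note shows. Statements on the series, on what has been measured and on what is new or still open speak of the compounds shown alone.

For the measured compounds named here, in an assay on HEK293 cells for agonist activity at transient receptor potential cation channel subfamily M member 8 (Homo sapiens), read by fluorescence and calcium flux, with a stated time of 15 min (on this read-out lower numbers stand for an effect already at smaller amounts and higher numbers for an effect only at larger amounts of compound), compound 2 `Cc1ccc(OCC(=O)N(Cc2cccs2)c2ccn(C)n2)cc1` gives 855 nM, the lower of the two numbers so far; compound 1 `Cc1ccc(OCC(=O)N(Cc2cccs2)C2COC2)cc1` gives 23000 nM. Going by the values given here, the single measured step, a 27-fold lower number from compound 1 to compound 2 (1.43 log units; beyond the scatter), concerns a saturated ring giving way to an aromatic one, whereas compound 3 `Cc1ccc(OCC(=O)N(Cc2cccs2)c2cccnc2)cc1` carries pyridin-3-yl in place of 1-methyl-1H-pyrazol-3-yl on an amide-type nitrogen, an exchange of one aromatic ring for another. Among the compounds with values here, no measured step covers such a swap, so that large step only loosely bears on it. A modest step of a 1.8-fold higher number from compound 2 to compound 3 (0.24 log units; within the scatter) is expected. Compound 3 is estimated at 1500 nM, within 400 nM to 6000 nM.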

Compound 3, half-maximal effective concentration: 198 nM
Compound 3: the middle estimate sits 7.6-fold (0.88 log units) above what was measured; the measured number lies below the stated range.
By their numbers in this assay, from the lowest: compound 3; then compound 2; then compound 1.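

Exchanging one aromatic ring for another on the amide-type nitrogen is not neutral in this assay: pyridin-3-yl in place of 1-methyl-1H-pyrazol-3-yl gives a 4.3-fold lower number from compound 2 to compound 3 (0.64 log units; beyond the scatter). Measured against oxetan-3-yl, the same place now spans a 120-fold lower number from compound 1 to compound 3 (2.07 log units; beyond the scatter), and compound 3 has the lowest number of the three. Nothing available explains the gain from this swap.

On these data alone, the swap changes ring size and hetero atom count together, so their separate contributions remain open. Whether phenyl on this nitrogen would retain the low number is also unresolved.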